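The source may hold more compounds than are shown below. What is called first, only, known or untested is meant among the compounds shown, and "the series" means these compounds.

Measured compounds in an ADME assay on HeLa cells (Homo sapiens) for cytotoxicity; on this read-out higher numbers stand for lower toxicity in this test and lower numbers for higher toxicity in this test:
compound 1 `CCN(CC)CN1C(=O)/C(=N/NC(N)=S)c2cc(Cl)ccc21` – > 100000 nM, a limit of the assay
compound 2 `CCN(CC)CN1C(=O)/C(=N/NC(N)=S)c2ccccc21` – > 100000 nM, a limit of the assay
compound 3 `CCN(CC)CN1C(=O)/C(=N/NC(=S)Nc2ccc(Cl)cc2)c2cc(Cl)ccc21` – 9400 nM

Within the data shown here, compound 3 holds the only actual number in this set; the other two values sit at the limit of > 100000 nM in this assay, at which 2 of the 3 values shown sit, and are limits rather than numbers. The next compound is compound 4 `CCN(CC)CN1C(=O)/C(=N/NC(=S)Nc2ccccc2)c2cc(Cl)ccc21`. Its difference from compound 3: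
hydrogen in place of chloro on an aromatic carbon

Among the measured compounds shown here, two measured steps bear on this. The same change on the core ring, a step that the two limits leave unreadable from compound 1 to compound 2, cannot be read, as both ends are limits. The step that brings in the 4-chlorophenyl, an at least 10-fold lower number from compound 1 to compound 3 (1.02 log units; beyond the scatter), was large and lowered the number; the chloro that now leaves was part of the group that entered there. In this assay a step toward a higher number is therefore expected for compound 4, of modest size and possibly within the scatter. The expected step is a 2.1-fold higher number from compound 3 to compound 4 (0.33 log units; beyond the scatter). Compound 4 is estimated at 20000 nM, with a range from 7000 nM to 60000 nM.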

Compound 4, half-maximal cytotoxic concentration: 13500 nM
Beside the measured number, compound 4's estimate is 1.5-fold (0.17 log units) above it; the measured number falls inside the stated range.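

In this assay, exchanging 4-chlorophenyl for phenyl gives a 1.4-fold higher number from compound 3 to compound 4 (0.16 log units; within the scatter), so the chloro on this outer ring can leave without a change that stands clear of the scatter. Phenyl on the amide-type nitrogen still gives an at least 7.4-fold lower number from compound 1 to compound 4 (0.86 log units; beyond the scatter), which shows that the lower number first seen with the 4-chlorophenyl does not depend on this chloro. That step has a limit of the assay at one end, so it gives a bound and not an exact size: the limit of > 100000 nM in this assay, at which 2 of the 4 values shown sit.

Still open, on these data alone, is whether an aromatic ring is needed on this nitrogen at all, or whether a short chain such as ethyl or a benzyl group would give a similar number. Also open, as far as these compounds go, are the effect of a methoxy or a fluoro at the place of this chloro and the role of the chloro on the shared core, whose only step cannot be read.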